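From Methoxy to Benzamido: An Expected Cytotoxicity Step

The compounds below may be only part of what the source reports. "The series", "measured", "known", "first", "only" and "open" are said of these compounds alone.

In an ADME assay on Vero cells (Chlorocebus sabaeus) for cytotoxicity, read by MTT assay, with a stated time of 72 h (on this read-out lower numbers stand for stronger inhibition and higher numbers for weaker inhibition), three compounds have been measured so far:

Compound 1, `COc1cccc(-c2csc(NC(=O)c3ccc([N+](=O)[O-])o3)n2)c1`: 58700 nM
Compound 2, `CCOc1cccc(-c2csc(NC(=O)c3ccc([N+](=O)[O-])o3)n2)c1`: > 90000 nM, which is a limit of the assay
Compound 3, `CC(C)Oc1cccc(-c2csc(NC(=O)c3ccc([N+](=O)[O-])o3)n2)c1`: 69500 nM

Compound 1 stands lowest of the two numbers shown; its nearest neighbour is compound 3, with a 1.2-fold higher number from compound 1 to compound 3 (0.07 log units; within the scatter). For compound 2 only a limit is known, (the limit of > 90000 nM in this assay, at which 1 of the 3 values shown sits).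

Compound 4, `O=C(Nc1cccc(-c2csc(NC(=O)c3ccc([N+](=O)[O-])o3)n2)c1)c1ccccc1`, differs from compound 1 in one place: benzamido in place of methoxy on an aromatic carbon. The measured steps all concern the alkyl group on the oxygen of the aromatic ring: an at least 1.5-fold higher number from compound 1 to compound 2 (0.18 log units; that floor lies within the scatter) and an at least 1.2-fold lower number from compound 2 to compound 3 (0.11 log units; that floor lies within the scatter). None of them replaces the oxygen-bearing group itself, so none speaks directly to the change toward compound 4; they only show that small changes at this position left the read-out within the scatter. On that basis the expected step is a 1.0-fold higher number from compound 1 to compound 4 (0.01 log units; within the scatter), with no change beyond the scatter.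

Compound 4 is therefore estimated at 60000 nM in this assay, with a range from 25000 nM to 90000 nM.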

Compound 4, half-maximal inhibitory concentration: 50200 nM
Compound 4: the middle estimate sits 1.2-fold (0.08 log units) above what was measured; measured number inside the range.
By their numbers in this assay, from the lowest: compounds 4, 1 and 3 (each within the scatter of the next). At a limit, above all of these: compound 2.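

Benzamido is a much bigger group than the small ethers, bringing an added aromatic ring and an amide hydrogen, yet this assay gives a 1.2-fold lower number from compound 1 to compound 4 (0.07 log units; within the scatter) and a 1.4-fold lower number from compound 3 to compound 4 (0.14 log units; within the scatter). The earlier compounds shown here changed only the alkyl group on the oxygen, whereas this result shows that the entire oxygen-bearing group can be replaced with no shift beyond the scatter in these compounds. The remaining step, an at least 1.7-fold lower number from compound 2 to compound 4 (0.25 log units; that floor lies within the scatter), starts from a limit rather than a number and separates nothing further: the limit of > 90000 nM in this assay, at which 1 of the 4 values shown sits.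

From the compounds shown here alone, whether an amine or a carboxylic acid at this position would move the number beyond the scatter remains open. Going by these compounds, it is also open whether a fluorine or a methoxy on the benzamido ring would change the picture.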